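Sulfonamide replacements on a shared core against pancreatic cells

A few compounds are considered here, and "the series" means these few. Any claim that something is new, unique, unknown or untested is made for them only; others in the source may bear on it.

Compound 1 `CCOC(=O)[C@@H]1CCCN(S(=O)(=O)c2ccc(S(=O)(=O)N3CCCCC3)cc2)C1` carries a piperidinylsulfonyl group and, in a functional assay on MIA PaCa-2 cells (Homo sapiens) for inhibition, read by MTT assay, with a stated time of 3 days (on this read-out lower numbers stand for stronger inhibition and higher numbers for weaker inhibition), compound 1 gives only a limit, > 10000 nM. Compound 2 `CCOC(=O)[C@@H]1CCCN(S(=O)(=O)c2ccc(S(=N)(=O)N(CC)CC)cc2)C1` replaces that group with a diethyl sulfonimidoyl group; in this assay compound 2 likewise reaches only a limit, > 10000 nM. Both values sit at the same limit (the limit of > 10000 nM in this assay, at which 2 of the 2 values shown sit), so the step from compound 1 to compound 2 cannot be read: a step that the two limits leave unreadable from compound 1 to compound 2. Going by the values given here, compound 2 therefore stands at the limit, alongside the only other compound measured.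

Compound 3 `CCOC(=O)[C@@H]1CCCN(S(=O)(=O)c2ccc(S(=O)(=O)N(CC)C(C)C)cc2)C1` is the next variation. Relative to compound 2 the change is a group of 9 heavy atoms (5 carbon, 1 nitrogen, 2 oxygen, 1 sulfur; no ring) in place of a group of 8 heavy atoms (4 carbon, 2 nitrogen, 1 oxygen, 1 sulfur; no ring), on an aromatic carbon; the entering ethyl(isopropyl)sulfamoyl group returns to a sulfonyl arrangement and removes the hydrogen-bond donor of compound 2. Among the compounds with values here, the one measured step that bears on this position is the unreadable one between compound 1 and compound 2, and it gives no size and no direction. With two limits at the same place, the expected step from compound 2 to compound 3 is a step that the limit leaves unreadable from compound 2 to compound 3, which amounts to no readable change. Compound 3 is estimated to give 15000 nM in this assay, with a range from 4000 nM to 60000 nM, most probably again as a limit.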

Compound 3, half-maximal inhibitory concentration: > 10000 nM
Compound 3: only a limit was reported (the forecaster's own chance of this, stated with the estimate: 85%); the middle value is on the limit's open side.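

In this assay compound 3 gives > 10000 nM, which is a limit. No step among compound 1, compound 2 and compound 3 can be read: the limit of > 10000 nM in this assay, at which 3 of the 3 values shown sit.

The compounds shown leave open whether exchanging these groups changes inhibition at all, since none of the three gives a value beyond a limit.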